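The compounds below may be only part of what the source reports. "The series", "measured", "known", "first", "only" and "open" are said of these compounds alone.

In an ADME assay on HEK293 cells (Homo sapiens) for cytotoxicity, with a stated time of 72 h (a higher number here means that more compound is needed for the effect, a lower number that less compound is needed), compound 1 `C=C[C@@](C)(/C=C/c1ccc(O)cc1)CCC=O` gives > 36600 nM, which is a limit of the assay and not a number. Compound 2 `C=C[C@@](C)(/C=C/c1ccc(O)cc1)CC/C=C/C(=O)OCc1ccccc1` also gives only a limit, > 36600 nM. Compound 3 `C=C[C@@](C)(/C=C/c1ccc(O)cc1)CC/C=C/C(=O)c1ccccc1` likewise gives only a limit, > 36600 nM. The whole set is summed up by the limit of > 36600 nM in this assay, at which 3 of the 3 values shown sit, so compound 1 cannot be ranked against the other two. For the measured compounds named here, the single measured step, a step that the two limits leave unreadable from compound 2 to compound 3, has no size that can be carried forward.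

Compound 4 `C=C[C@@](C)(/C=C/c1ccc(O)cc1)CC/C=C(C)/C=N/N` has not yet been measured. It differs from compound 1 by a group of 6 heavy atoms (4 carbon, 2 nitrogen; no ring) in place of a group of 2 heavy atoms (1 carbon, 1 oxygen; no ring), on a saturated chain carbon, three bonds along the chain from two double-bonded chain carbons: the formyl group leaves, and a larger group with no common name enters on a saturated chain carbon, three bonds along the chain from two double-bonded chain carbons. Going by the values given here, none of the measured compounds carries this group, so the evidence bears on it only indirectly. For compound 4, no step beyond the scatter is expected in this assay because of the limit of > 36600 nM in this assay, at which 3 of the 3 values shown sit, although a limit shared by three compounds cannot exclude a real fall. The expected step is a step that the limit leaves unreadable from compound 1 to compound 4. For compound 4 the estimated value is 40000 nM, with an expected range from 15000 nM to 80000 nM, and the assay may well report only a limit again.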

Compound 4, half-maximal effective concentration: > 36600 nM
Compound 4: a limit, no number (the forecaster's own chance of this, stated with the estimate: 70%); the middle value lies beyond the limit too.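

In this assay compound 4 gives > 36600 nM, which is a limit of the assay and not a number. Compound 1 also stands only at a limit, so no step can be read between compound 1 and compound 4. The compounds shown leave open at what concentration, if any, each would reach its half-maximal effect: the limit of > 36600 nM in this assay, at which 4 of the 4 values shown sit.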